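The source may report more compounds than this note shows. Statements on the series, on what has been measured and on what is new or still open speak of the compounds shown alone.

Working notes on the series. The three measured compounds are compound 1 `Cc1c[nH]cc1C(=O)O`, compound 2 `Cc1cc(C(=O)O)c(C)n1-c1cccc(C#N)c1` and compound 3 `COCCNC(=O)C1CCN(c2ccc(Cl)c(C(F)(F)F)c2)C1`. In an assay on cells for inhibition of Palmitoleoyl-protein carboxylesterase NOTUM variant C330S (Homo sapiens), read by fluorescence, with a stated time of 40 min (a higher number here means a weaker inhibitor, a lower number a stronger inhibitor), compound 1 gives 100000 nM, compound 2 gives 3100 nM and compound 3 gives 3500 nM. Compound 3 stands with compound 2 within the scatter of each other in this assay, while compound 1 stands beyond it with the higher number. Compound 4 `O=C(C1CCN(c2ccc(Cl)c(C(F)(F)F)c2)C1)N1CCCC1` is not yet measured; it differs from compound 3 by pyrrolidin-1-yl in place of (2-methoxyethyl)amino on a carbonyl carbon. Going by the values given here, no step between measured compounds touches this site, and nothing in the data points in either direction, so no change beyond the scatter is expected: the step of a 1.2-fold lower number from compound 3 to compound 4 (0.07 log units; within the scatter) is the estimate. Compound 4 is thus expected at about 3000 nM, in the range 1000 nM to 10000 nM.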

Compound 4, half-maximal inhibitory concentration: 410 nM
Compound 4: the middle estimate sits 7.3-fold (0.86 log units) above what was measured; measured number outside the range, below it.
By their numbers in this assay, from the lowest: compound 4; then compounds 2 and 3 (each within the scatter of the next); then compound 1.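

In this assay, the group on the carbonyl carbon proves to be a site that moves the number: pyrrolidin-1-yl in place of (2-methoxyethyl)amino gives an 8.5-fold lower number from compound 3 to compound 4 (0.93 log units; beyond the scatter). The heavy-atom count stays the same, while the ring, the amide hydrogen and the ether oxygen all change in this single step. Nothing on hand accounts for the step. Which of these changes carries the step remains open, and so does the response of this site to dimethylamino, (2-methoxyethyl)(methyl)amino or piperidin-1-yl on the same carbonyl carbon.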